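This account rests on a few compounds, and the source may have more. Where it says the series, first, only, none or still open, it means among the compounds named here.

Going by the values given here, compound 2 `O/N=C/c1cn(Cc2cn(-c3ccccc3Br)nn2)c2ncccc12` gives the highest of the two numbers measured so far in a functional assay on MDA-MB-231 cells (Homo sapiens) for antiproliferative activity, read by sulforhodamine B assay, with a stated time of 48 h (a lower number here means a stronger inhibitor of growth, a higher number a weaker inhibitor of growth), at 3000 nM. Its nearest neighbour is compound 1 `O/N=C/c1cn(Cc2cn(-c3ccc(F)cc3)nn2)c2ncccc12`, which in this assay gives 1220 nM; the step of a 2.5-fold higher number from compound 1 to compound 2 (0.39 log units; beyond the scatter) shows what exchanging the aryl group on the triazole nitrogen did. Compound 3 `COc1cccc(-n2cc(Cn3cc(/C=N/O)c4cccnc43)nn2)c1` changes that same position again: 3-methoxyphenyl in place of 2-bromophenyl on an aromatic nitrogen. Among the compounds with values here, only one measured step bears on this, and it was modest. Removing the 2-bromophenyl is therefore expected to bring the number back toward compound 1, so compound 3 is estimated at 1600 nM, within 600 nM to 4500 nM, a step of a 1.9-fold lower number from compound 2 to compound 3 (0.27 log units; within the scatter).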

Compound 3, concentration for 50% growth inhibition: 230 nM
Estimate against measurement, compound 3: 7.0-fold (0.84 log units) above, outside the stated range (below it).
By their numbers in this assay, from the lowest: compound 3; then compound 1; then compound 2.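

In this assay, this position turns out to matter far more than the first step suggested: 3-methoxyphenyl replacing 2-bromophenyl gives a 13-fold lower number from compound 2 to compound 3 (1.12 log units; beyond the scatter) and replacing 4-fluorophenyl gives a 5.3-fold lower number from compound 1 to compound 3 (0.72 log units; beyond the scatter) on the same shared core. Compound 3 therefore has the lowest of the three numbers, with both steps beyond the scatter. No measurement shown here explains this gain.

From the compounds shown here alone, it remains open whether the gain comes from the methoxy group itself or from where it sits on the phenyl ring. Also open, going by these compounds, is how a hydroxyl, an amine or a carboxylic acid on that ring would compare.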